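This account rests on a few compounds, and the source may have more. Where it says the series, first, only, none or still open, it means among the compounds named here.

Compound 1 `CCCCCc1ccc(-c2cc3cn([C@H]4C[C@H](O)[C@@H](COC(=O)[C@@H](NC(=O)[C@@H]5CCCN5C(=O)[C@@H](N)CC(N)=O)C(C)C)O4)c(=O)nc3o2)cc1` gives 56000 nM 
Compound 2 `CCCCCc1ccc(-c2cc3cn([C@H]4C[C@H](O)[C@@H](COC(=O)[C@@H](NC(=O)[C@@H]5CCCN5C(=O)[C@@H](N)CCCCN)C(C)C)O4)c(=O)nc3o2)cc1` gives 29000 nM 
Compound 3 `CCCCCc1ccc(-c2cc3cn([C@H]4C[C@H](O)[C@@H](COC(=O)[C@@H](NC(=O)[C@@H]5CCCN5C(=O)[C@@H](N)CC(=O)O)C(C)C)O4)c(=O)nc3o2)cc1` is not yet measured

In an ADME assay on HEL cells (Homo sapiens) for inhibition (on this read-out higher numbers stand for lower toxicity in this test and lower numbers for higher toxicity in this test), compound 2 gives 29000 nM and sits within the scatter of compound 1 at 56000 nM on the two numbers available. The change to compound 3 is carboxy in place of 3-aminopropyl on a saturated chain carbon, two bonds along the chain from an amine nitrogen and a carbonyl carbon. Among the measured compounds shown here, the only measured step at this place, a 1.9-fold lower number from compound 1 to compound 2 (0.29 log units; within the scatter), is small, so no step beyond the scatter is expected. The expected size is a 1.6-fold higher number from compound 2 to compound 3 (0.19 log units; within the scatter) in this estimate. Compound 3 is estimated at 45000 nM with an expected range from 20000 nM to 100000 nM as a working figure.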

Compound 3, half-maximal cytotoxic concentration in the HEL assay: 52000 nM
Estimate against measurement, compound 3: 1.2-fold (0.06 log units) below, and the stated range covers the measured number.
By their numbers in the HEL assay, from the lowest: compounds 2, 3 and 1 (each within the scatter of the next).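

In the HEL assay, carboxy in place of 3-aminopropyl gives a 1.8-fold higher number from compound 2 to compound 3 (0.25 log units; within the scatter), and hydroxy in place of amino on a carbonyl carbon gives a 1.1-fold lower number from compound 1 to compound 3 (0.03 log units; within the scatter). At this place, carboxy therefore joins carbamoyl and 3-aminopropyl with no step beyond the scatter among the three compounds. In a physicochemical assay, read by HPLC, in phosphate buffer, with a stated time of 24 h, at pH 7.4 (a lower number here means that less of the compound is left, a higher number that more of the compound is left), compound 2 gives > 95%, which is a limit of the assay. In the physicochemical assay, compound 3 gives > 95%, which is also a limit of the assay. In the physicochemical assay, the step from compound 2 to compound 3 cannot be read, as both values are limits of the assay: the limit of > 95% in the physicochemical assay, at which 2 of the 2 values shown sit.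

Going by these compounds, whether a methyl group or a longer chain ending in a carboxylic acid at this place would give a step beyond the scatter in the HEL assay remains open.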